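Hydroxymethyl on the Carbon Bound to the Amine Nitrogen

The source may report more compounds than this note shows. Statements on the series, on what has been measured and on what is new or still open speak of the compounds shown alone.

Measured so far in a toxicity assay on MDCK cells (Canis lupus familiaris) for cytotoxicity, read by crystal violet staining, with a stated time of 48 h; a higher number here means that more compound is tolerated, a lower number that less compound is tolerated:
compound 1 `Cc1ccc2[nH]c(=O)c(CN(Cc3ccccc3)Cc3ccc(C(C)(C)C)cc3)cc2c1`: > 5000 nM
compound 2 `CCCc1ccc2[nH]c(=O)c(CN(Cc3ccc(F)cc3)Cc3ccc(C(C)(C)C)cc3)cc2c1`: 8400 nM

Compound 1 gives only a limit in this assay, > 5000 nM, not a number. Compound 1 sits at the limit of > 5000 nM in this assay, at which 1 of the 2 values shown sits. Compound 2 gives 8400 nM. Compound 3 `Cc1ccc2[nH]c(=O)c(CN(Cc3ccc(C(C)(C)C)cc3)[C@H](CO)c3ccccc3)cc2c1` differs from compound 1 by hydroxymethyl in place of hydrogen on a saturated chain carbon bound to an amine nitrogen and an aromatic carbon. For the measured compounds named here, no step between measured compounds is available, so the effect of this change on cytotoxicity is unknown from these data. For compound 3 the step that the limit leaves unreadable from compound 1 to compound 3 is expected to stay within the scatter. Compound 3 is therefore estimated at 8000 nM, between 3000 nM and 25000 nM.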

Compound 3, half-maximal cytotoxic concentration: > 10000 nM
Compound 3: a limit, no number (the forecaster's own chance of this, stated with the estimate: 50%); middle value at least 1.2-fold (0.09 log units) away from the limit.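

For the compounds shown here, compound 1 and compound 3 both give only limits in this assay, so no step between them can be read. The compounds shown leave open whether hydroxymethyl in place of hydrogen on this carbon changes cytotoxicity at all.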